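Three Measured Compounds and One Awaiting Its Number

The source may hold more compounds than are shown below. What is called first, only, known or untested is meant among the compounds shown, and "the series" means these compounds.

Compound 1 `COC(=O)CNC1=CS(=O)(=O)O[C@@]12[C@@H](CO[Si](C)(C)C(C)(C)C)O[C@@H](n1cc(C)c(=O)n(C)c1=O)[C@@H]2O[Si](C)(C)C(C)(C)C` — 96000 nM
Compound 2 `Cc1cn([C@@H]2O[C@@H]3COC4(O)CS(=O)(=O)O[C@@]34[C@H]2O)c(=O)[nH]c1=O` — 100000 nM
Compound 3 `Cc1cn([C@@H]2O[C@@H]3COC4(O)CS(=O)(=O)O[C@@]34[C@H]2O[Si](C)(C)C(C)(C)C)c(=O)[nH]c1=O` — 100000 nM

In a functional assay on CCRF-CEM cells (Homo sapiens) (on this read-out higher numbers stand for lower toxicity in this test and lower numbers for higher toxicity in this test), compound 1 stands at the lowest of the three numbers, but compound 2 is the nearest and compound 3 the furthest, and both gaps are within the scatter, so no order among the three can be read from these values. Among the measured compounds shown here, the only step between compounds that differ in one place is no change at the digits printed from compound 2 to compound 3 (within the scatter), where a group of seven heavy atoms replaces a hydrogen atom on an oxygen on a saturated carbon; it leaves the read-out unchanged within the scatter.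

Compound 4 `COC(=O)C(=O)CNC1=CS(=O)(=O)O[C@@]12[C@@H](CO[Si](C)(C)C(C)(C)C)O[C@@H](n1cc(C)c(=O)n(C)c1=O)[C@@H]2O[Si](C)(C)C(C)(C)C` has not yet been measured. It differs from compound 1 by methoxycarbonyl in place of methoxy on a carbonyl carbon. For the measured compounds named here, no measured step touches the same place, so the one step that exists bears on it only as a general sign that a change in the periphery of this shared core has so far left the read-out where it was. Compound 4 is therefore expected to give 96000 nM, with a range from 40000 nM to 200000 nM. The expected step is no change at the digits printed from compound 1 to compound 4 (within the scatter), which is estimated to stay within the scatter.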

Compound 4, half-maximal cytotoxic concentration: 5570 nM
The estimate for compound 4 lay 17-fold (1.24 log units) above the measured number; measured number below the stated range.
By their numbers in this assay, from the lowest: compound 4; then compounds 1, 2 and 3 (each within the scatter of the next).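

In this assay, among the compounds shown here, this carbonyl carbon, whose other neighbour is a saturated chain carbon, turns out to be a place where the read-out responds: methoxycarbonyl in place of methoxy gives a 17-fold lower number from compound 1 to compound 4 (1.24 log units; beyond the scatter), whereas the one earlier step, at a different place, was no change at the digits printed from compound 2 to compound 3 (within the scatter). Read one bond further out, the same difference is ((methoxycarbonyl)methyl)amino to (((methoxycarbonyl)carbonyl)methyl)amino, so a single change in this side chain on the shared core is enough to move the number in the direction of higher toxicity in this test. Nothing available accounts for the size or the direction of this step.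

The compounds shown leave open whether the step belongs to the added carbonyl alone or to the whole methoxycarbonyl group, a question that a carboxylic acid, an amide or a longer chain at this place would bear on. They also leave open whether the same change would have a comparable effect on a core carrying free hydroxyl groups in place of the silyl ethers of compound 1.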